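Stereochemistry in a tricyclic purine-sulfonamide series

The source may hold more compounds than are shown below. What is called first, only, known or untested is meant among the compounds shown, and "the series" means these compounds.

Measured compounds:
- compound 1, `O=[N+]([O-])c1ccc(S(=O)(=O)N2C[C@H](n3cnc4c(Cl)nc(Cl)nc43)OCc3ccccc32)cc1`: 110 nM
- compound 2, `O=[N+]([O-])c1ccccc1S(=O)(=O)N1CC(n2cnc3nc(Cl)nc(Cl)c32)OCc2ccccc21`: 318 nM
- compound 3, `O=[N+]([O-])c1ccccc1S(=O)(=O)N1CC(n2cnc3c(Br)ncnc32)OCc2ccccc21`: "not determined" (no result reported)

The read-out is a functional assay on MDA-MB-231 cells (Homo sapiens) for cytotoxicity, read by sulforhodamine B assay, with a stated time of 3 days; a lower number here means a stronger inhibitor, a higher number a weaker inhibitor. Compound 1 gives 110 nM, the lowest of the two numbers available. The nearest number is that of compound 2 at 318 nM, a gap that lies beyond the usual scatter of the assay. For compound 3 the entry reads "not determined" (no result reported), so no number is available for it and nothing can be said about where it stands.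

Compound 4, `O=[N+]([O-])c1ccc(S(=O)(=O)N2CC(n3cnc4c(Cl)nc(Cl)nc43)OCc3ccccc32)cc1`, is now to be measured in this assay. It differs from compound 1 as follows: the two compounds have the same atoms and bonds; at least one stereo element is drawn with a configuration in one of them and without one in the other: 1 of 1 stereo elements differ; a stereocentre at a saturated ring carbon is drawn R in compound 1 and without a configuration in compound 4. In words, the two compounds have the same atoms and bonds; the single stereocentre at a saturated ring carbon is drawn R in compound 1 and without a configuration in compound 4.

Within the data shown here, no step between two measured compounds with only this difference is available for comparison. Among the measured compounds shown here, the expectation is that the unresolved material behaves at most modestly weaker than the single drawn configuration of compound 1, with the step from compound 1 to compound 4 expected to be a 1.5-fold higher number from compound 1 to compound 4 (0.19 log units; within the scatter), likely within or close to the scatter. The estimate for compound 4 is therefore 170 nM, with a range from 75 nM to 400 nM.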

Compound 4, half-maximal inhibitory concentration: 166 nM
Compound 4: the middle estimate sits 1.0-fold (0.01 log units) above what was measured; the range from low to high includes it.
By their numbers in this assay, from the lowest: compounds 1, 4 and 2 (each within the scatter of the next, the first and the last beyond it).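

In this assay the series now has its first step at this stereocentre, and it is a purely stereochemical one: a 1.5-fold higher number from compound 1 to compound 4 (0.18 log units; within the scatter). Drawing the saturated ring carbon as R or leaving it without a configuration therefore gives no difference that can be separated from the scatter, which the earlier compounds could not show since no pair among them differed in this way alone. Any reading of this step rests on one fact: the fact that one of compounds 1 and 4 is drawn with a defined configuration and the other without, at the place where they differ

On these data alone, the drawing of compound 4 does not state which configurations it contains or in what proportion, so the value of the S configuration alone, and with it any preference between the two forms, remains open. Also open, as far as these compounds go, is whether this insensitivity holds when the rest of the core of compound 1 changes, for instance with an amine in place of a chlorine or a carboxylic acid in place of the nitro group.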